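Swapping the Aryl Group on the Shared Core

The source may report more compounds than this note shows. Statements on the series, on what has been measured and on what is new or still open speak of the compounds shown alone.

Of the compounds shown here, two have so far been measured in an assay on CHO cells for displacement of a labelled ligand from adenosine receptor A3 (Homo sapiens), read by scintillation counting, with a stated time of 3 h; on this read-out lower numbers stand for stronger inhibition and higher numbers for weaker inhibition. Compound 1 `COc1ccc(-c2nc3c(NC4CCCC4)ncnc3n2C)cc1` gives 1850 nM, the higher of the two numbers. Compound 2 `CCCn1c(-c2ccccc2)nc2c(NC3CCCC3)ncnc21` gives 749 nM, the lower one. Compound 3 `Cc1cccc(-c2nc3c(NC4CCCC4)ncnc3n2C)c1` differs from compound 1 in a single place: 3-methylphenyl in place of 4-methoxyphenyl on an aromatic carbon. For the measured compounds named here, no measured pair shows what this exchange does, so the direction rests on judgement alone. The step is expected to be small, no larger than the usual scatter, with a slight lean towards a lower number; the expected step is a 1.4-fold lower number from compound 1 to compound 3 (0.15 log units; within the scatter). Compound 3 is therefore estimated at 1300 nM, in a range from 450 nM to 4000 nM.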

Compound 3, inhibition constant: 510 nM
Compound 3: middle estimate off by 2.5-fold (0.41 log units), on the high side; the range from low to high includes it.
By their numbers in this assay, from the lowest: compounds 3 and 2 (each within the scatter of the next); then compound 1.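

This position, an aromatic carbon between two ring nitrogen atoms, proves sensitive to the aryl group it carries: 3-methylphenyl in place of 4-methoxyphenyl gives (a 3.6-fold lower number from compound 1 to compound 3 (0.56 log units; beyond the scatter)), a step beyond the scatter. Compound 1 and compound 2 differ in more than one place, so they could not isolate this position. No available evidence accounts for the step. The compounds shown leave open whether the methyl group itself or its place on the phenyl ring carries the step, a question that 3-methoxyphenyl and 4-methylphenyl would separate. From the compounds shown here alone, how a carboxylic acid on that ring would read also stays open.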